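Benzyl in place of isopropyl on the shared core

The source may hold more compounds than are shown below. What is called first, only, known or untested is meant among the compounds shown, and "the series" means these compounds.

Compound 1 `CCC[C@H]1NC(=O)c2csc(n2)[C@H](C)NC(=O)[C@H](C(C)C)N(C)C(=O)[C@H](Cc2ccccc2)N(C)C(=O)[C@H](C)OC(=O)[C@@H]1C` gives 1000 nM in a functional assay on KB cells (Homo sapiens) for cytotoxicity; on this read-out higher numbers stand for weaker inhibition and lower numbers for stronger inhibition. Compound 2 `CCC[C@H]1NC(=O)c2csc(n2)[C@H](C)NC(=O)[C@H](C(C)C)N(C)C(=O)[C@H](Cc2ccc(O)cc2)N(C)C(=O)[C@H](C)OC(=O)[C@@H]1C` carries a hydroxy on an aromatic carbon and gives 1000 nM in this assay; the step of no change at the digits printed from compound 1 to compound 2 (within the scatter) is within the scatter. Compound 2 therefore stands level with compound 1 on the numbers shown, and its nearest neighbour is compound 1.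

Compound 3 `CCC[C@H]1NC(=O)c2csc(n2)[C@H](C)NC(=O)[C@H](Cc2ccccc2)N(C)C(=O)[C@H](Cc2ccc(O)cc2)N(C)C(=O)[C@H](C)OC(=O)[C@@H]1C` differs from compound 2 by benzyl in place of isopropyl on a saturated ring carbon. Among the measured compounds shown here, no measured step exchanges this group on the saturated ring carbon; the only measured step, no change at the digits printed from compound 1 to compound 2 (within the scatter), concerns the aromatic hydroxy and bears on this change only as a sign that one variation on the shared core left this assay unmoved. The step of no change at the digits printed from compound 2 to compound 3 (within the scatter) is therefore expected to lie within the scatter, with no clear direction. Compound 3 is estimated at 1000 nM, between 300 nM and 3000 nM.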

Compound 3, half-maximal inhibitory concentration: 1000 nM
The estimate for compound 3 equals the measured number at the digits printed, and the stated range covers the measured number.
By their numbers in this assay, from the lowest: compounds 1, 2 and 3 (each within the scatter of the next).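

In this assay, among the compounds shown here, the exchange of isopropyl for benzyl on the saturated ring carbon gives no change at the digits printed from compound 2 to compound 3 (within the scatter) and is the first measured change at this position, where the earlier pair spoke only to the aromatic hydroxy. The position therefore carries a group with a six-membered aromatic ring as well as one with no ring, with the read-out level for both. No supporting data bear on this result.

Going by these compounds, whether an amine, a carboxylic acid or a longer chain on this carbon would shift the read-out stays open, as does whether benzyl gives the same result alongside the unsubstituted benzyl of compound 1 rather than the 4-hydroxybenzyl group of compound 2. With all three compounds level, the set does not yet show which places on the shared core, if any, move this read-out.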